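Removing the phenolic hydroxy from a weak calcium channel blocker

This account rests on a few compounds, and the source may have more. Where it says the series, first, only, none or still open, it means among the compounds named here.

Measured compounds:
compound 1, `CN(Cc1ccc(OCCCN)cc1)c1nc2ccc(Oc3ccccc3)cc2s1` — 49000 nM in an assay on SH-SY5Y cells for inhibition of Voltage-dependent N-type calcium channel subunit alpha-1B (Homo sapiens), read by FLIPR and calcium flux, with stated times of 600 s and 300 s, in the presence of a further agent that is not named here; a lower number here means a stronger inhibitor, a higher number a weaker inhibitor
compound 2, `CN(Cc1ccc(OCCCNC(=N)N)cc1)c1nc2ccc(Oc3ccc(O)cc3)cc2s1` — 432000 nM in this assay

Compound 2 stands at the highest of the two numbers in this assay; compound 1 gives the lower one, a gap beyond the usual scatter. Compound 3, `CN(Cc1ccc(OCCCNC(=N)N)cc1)c1nc2ccc(Oc3ccccc3)cc2s1`, differs from compound 2 by hydrogen in place of hydroxy on an aromatic carbon, so that compound 3 carries the plain phenoxy group found in compound 1. Since compound 1 with that phenoxy group gives 49000 nM, the step from compound 2 to compound 3 in this assay is expected to lower the number, by more than the scatter, a 4.3-fold lower number from compound 2 to compound 3 (0.64 log units; beyond the scatter). Compound 3 is estimated at 100000 nM, within 30000 nM to 350000 nM.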

Compound 3, half-maximal inhibitory concentration: 113000 nM
Estimate against measurement, compound 3: 1.1-fold (0.05 log units) below; the range from low to high includes it.
By their numbers in this assay, from the lowest: compound 1; then compound 3; then compound 2.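

In this assay, the change from 4-hydroxyphenoxy to phenoxy alone lowers the number (a 3.8-fold lower number from compound 2 to compound 3 (0.58 log units; beyond the scatter)), so hydrogen on this aromatic carbon gives a stronger inhibitor than hydroxy, though still a weak one. With the phenoxy group held constant, the group placed on the amine nitrogen raises the number (a 2.3-fold higher number from compound 1 to compound 3 (0.36 log units; beyond the scatter)), and this is a separate modest loss. Nothing measured here explains either step.

As far as these compounds go, whether a methoxy group or a fluorine at this position would match hydroxy or hydrogen remains open. So does whether hydroxy would cost as much in the compound with the free amine, or with a longer chain.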